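Making one ring aromatic in compound 3

The compounds below may be only part of what the source reports. "The series", "measured", "known", "first", "only" and "open" are said of these compounds alone.

Three related compounds have been measured in a physicochemical assay for lipophilicity, using the shake flask method, measured as octanol-water partition, at pH 7.4; on this read-out higher numbers stand for higher lipophilicity and lower numbers for lower lipophilicity. Compound 1 `CC(=O)N[C@@H]1CCC[C@H](C(=O)Nc2cc(-c3cnn4c3CCCC4)c(F)cn2)C1` gives 2.9, compound 2 `CC(=O)N[C@@H]1CCC[C@H](C(=O)Nc2cc(-c3cnn4ccccc34)c(Cl)cn2)C1` gives 3.6, and compound 3 `CC(=O)N[C@@H]1CCC[C@H](C(=O)Nc2cc(-c3cnc4n3CCCC4)c(Cl)cn2)C1` gives 2.7. Compound 3 lies within the usual scatter of compound 1, so those two cannot be told apart, while compound 2 stands clearly higher than both.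

Within the data shown here, compound 4 `CC(=O)N[C@@H]1CCC[C@H](C(=O)Nc2cc(-c3cnc4ccccn34)c(Cl)cn2)C1` has no measurement yet. It differs from compound 3 in one group: a group of 9 heavy atoms (7 carbon, 2 nitrogen; one five-membered aromatic ring with 2 hetero atoms, one six-membered aromatic ring with 1 hetero atom) in place of a group of 9 heavy atoms (7 carbon, 2 nitrogen; one five-membered aromatic ring with 2 hetero atoms, one six-membered non-aromatic ring with 1 hetero atom), on an aromatic carbon. That group sits on an aromatic carbon, ortho to a chloro group and opposite the ring nitrogen. In short, a six-membered non-aromatic ring gives way to a six-membered aromatic ring.

Among the measured compounds shown here, one measured step bears on this: a number 0.90 log units lower from compound 2 to compound 3 (beyond the scatter). It ran the opposite way, from the aromatic to the non-aromatic six-membered ring, so reading it backwards points to a higher number. However, the group entering compound 4 has the same counts as the group in compound 2 without being the same group, and the data do not show how much that difference matters. Only part of the reversed step is therefore expected, and the expected change is a number 0.40 log units higher from compound 3 to compound 4 (beyond the scatter). For compound 4 the estimated value in this assay is 3.1, with an expected range from 2.7 to 3.5.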

Compound 4, distribution coefficient: 3
Estimate against measurement, compound 4: 0.10 log units above; low and high end bracket the measured number.
By their numbers in this assay, from the lowest: compounds 3, 1 and 4 (each within the scatter of the next); then compound 2.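

Compound 2 and compound 4 carry groups with identical counts, two fused aromatic rings with the same atoms, yet the printed step is a number 0.60 log units lower from compound 2 to compound 4 (beyond the scatter) in this assay. Among these compounds, at this position, then, the counts of a group do not settle the read-out, and how the same atoms are arranged within the group makes a measurable difference, something the earlier compounds could not separate from the loss of aromaticity. Making the six-membered ring aromatic while keeping the arrangement of compound 3 gives a number 0.30 log units higher from compound 3 to compound 4 (within the scatter), so this pair cannot be told apart and an aromatic six-membered ring alone does not guarantee a number as high as that of compound 2; nothing measured here explains why the arrangement of the atoms matters.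

Compound 1 differs from the others in more than one place, so the compounds shown do not say whether the chloro group has any influence on these results. Also open, as far as these compounds go, is whether the same pattern would hold with a methyl group or a nitrile in place of the chloro group, or with a third nitrogen in the fused rings.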